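This account rests on a few compounds, and the source may have more. Where it says the series, first, only, none or still open, it means among the compounds named here.

Compound 1 `CCOC(=O)C12C(=O)OCC=C1COC2c1ccccc1` in a functional assay on QGY cells (Homo sapiens) for cytotoxicity, read by MTT assay (a lower number here means a stronger inhibitor, a higher number a weaker inhibitor), gives > 1000000 nM, a limit rather than a number.
Compound 2 `CCOC(=O)C12C(=O)OCC=C1COC2c1ccc(OC)c(OC)c1` in this assay gives > 1000000 nM, again only a limit.
Compound 3 `CCOC(=O)C12C(=O)OCC=C1COC2c1cc(OC)cc(OC)c1` in this assay gives > 1000000 nM, likewise a limit.

Going by the values given here, compound 1 therefore stands at the limit of > 1000000 nM in this assay, at which 3 of the 3 values shown sit, and no measured pair shows a step that could be sized. Compound 4 `CCOC(=O)C12C(=O)OCC=C1COC2c1ccc([N+](=O)[O-])cc1` carries the change (nitro in place of hydrogen on an aromatic carbon), nitro in place of hydrogen on an aromatic carbon. With every value shown sitting at the same limit, no direction can be drawn from the data, and the step from compound 1 to compound 4 is expected to be none beyond the scatter, that is a step that the limit leaves unreadable from compound 1 to compound 4. For compound 4 in this assay, a value of 2000000 nM is estimated, with a range from 200000 nM to 20000000 nM, most likely reported only as a limit.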

Compound 4, half-maximal inhibitory concentration: > 1000000 nM
Compound 4: no number, only a limit (the forecaster's own chance of this, stated with the estimate: 85%); the middle value is on the limit's open side.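

Going by these compounds alone, compound 1 and compound 4 both give only a limit, so no step between them can be read: the limit of > 1000000 nM in this assay, at which 4 of the 4 values shown sit. Whether any change on the aromatic ring shifts the result in this assay stays open, and none of the compounds shown gives a number.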